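Aryl-to-methyl swap at the ring amine of compound 1

The source may report more compounds than this note shows. Statements on the series, on what has been measured and on what is new or still open speak of the compounds shown alone.

Compound 1 `Fc1ccc(N2CCN(c3nc(-n4ccc5ccccc54)c4ccccc4n3)CC2)cc1` is read in a functional assay on KB cells (Homo sapiens) for antiproliferative activity, read by MTT assay (on this read-out lower numbers stand for stronger inhibition and higher numbers for weaker inhibition), and gives 50 ug/mL. Among the measured compounds shown here, its only measured neighbour is compound 2 `c1ccc(N2CCN(c3nc(-n4ccc5ccccc54)c4ccccc4n3)CC2)cc1`, which in this assay gives 50 ug/mL. The step of no change at the digits printed from compound 1 to compound 2 (within the scatter) shows that exchanging hydrogen for fluoro on the aromatic carbon leaves the read-out unchanged, so compound 1 stands level with compound 2 at the digits shown, and nothing in the pair separates them.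

Compound 3 `CN1CCN(c2nc(-n3ccc4ccccc43)c3ccccc3n2)CC1` is not yet measured. The change from compound 1 is methyl in place of 4-fluorophenyl on an amine nitrogen in a ring. For the measured compounds named here, this is a different kind of change from the one measured step, which touched only a substituent on the aryl ring; no measured step removes the whole aryl group from the ring amine, so the step of no change at the digits printed from compound 1 to compound 2 (within the scatter) gives no direct guide to its size or direction.

Going by the values given here, with the one measured step flat, the expectation for compound 3 is set at the level of the series, with the step of no change at the digits printed from compound 1 to compound 3 (within the scatter) and a wide range to reflect the missing precedent. Compound 3 is estimated at 50 ug/mL, in the range 20 ug/mL to 120 ug/mL.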

Compound 3, half-maximal inhibitory concentration: 4.9 ug/mL
For compound 3 the middle estimate is 10-fold (1.01 log units) above the measured one; the measured number lies below the stated range.
By their numbers in this assay, from the lowest: compound 3; then compounds 1 and 2 (each within the scatter of the next).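

In this assay the ring amine turns out to be a position where the read-out moves: replacing the aryl group with methyl lowers the number sharply, both with the fluoro substituent present (a 10-fold lower number from compound 1 to compound 3 (1.01 log units; beyond the scatter)) and without it (a 10-fold lower number from compound 2 to compound 3 (1.01 log units; beyond the scatter)). The fluoro-to-hydrogen exchange on the aryl ring had left the number in place, so the group on the amine nitrogen in the ring counts for far more on this read-out than that substituent does, at least across these compounds. Nothing shown here explains why the exchange of aryl for methyl has so large an effect.

On these data alone, what remains open is how the number responds to other groups at this nitrogen, and whether methyl itself matters or the gain comes simply from the aryl ring leaving. A hydrogen on the ring amine, an ethyl group, a longer chain ending in a hydroxyl or an amine, or a benzyl group would show whether the number keeps falling, holds or climbs back towards that of the aryl compounds.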